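Sulfonate series: ring methoxy removal, compound 4 pending

The compounds below may be only part of what the source reports. "The series", "measured", "known", "first", "only" and "open" are said of these compounds alone.

Measured compounds:
compound 1, `COc1cccc(OS(=O)(=O)c2ccc(N3CCN(C)C3=O)cc2)c1`, 1600 nM
compound 2, `COc1ccc(OS(=O)(=O)c2ccc(N3CCN(C)C3=O)cc2)cc1OC`, 8500 nM
compound 3, `CCN1CCN(c2ccc(S(=O)(=O)Oc3ccc(OC)c(OC)c3)cc2)C1=O`, 35000 nM

All three were run in a functional assay on M21 cells (Homo sapiens) for antiproliferative activity, read by sulforhodamine B assay, with a stated time of 48 h; a higher number here means a weaker inhibitor, a lower number a stronger inhibitor. Compound 3 gives the highest number of the three, with 35000 nM, and compound 1 the lowest. Compound 3 differs from compound 2 by methyl in place of hydrogen on a saturated chain carbon bound to an amide-type nitrogen in a ring, and that step reads a 4.1-fold higher number from compound 2 to compound 3 (0.61 log units; beyond the scatter). Compound 1 differs from compound 2 by hydrogen in place of methoxy on an aromatic carbon, a step of a 5.3-fold lower number from compound 2 to compound 1 (0.73 log units; beyond the scatter).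

Compound 4, `CCN1CCN(c2ccc(S(=O)(=O)Oc3ccc(OC)cc3)cc2)C1=O`, is not yet measured in this assay. It differs from compound 3 by hydrogen in place of methoxy on an aromatic carbon. This is the same kind of change as that from compound 2 to compound 1, but not the same: in compound 2 the leaving methoxy is para to a large group, in compound 3 it is meta to a large group, while both are ortho to a methoxy group. The estimate for compound 4 rests on compound 3 at 35000 nM and on the step of a 5.3-fold lower number from compound 2 to compound 1 (0.73 log units; beyond the scatter), tempered for the different place, so a step of a 3.9-fold lower number from compound 3 to compound 4 (0.59 log units; beyond the scatter) is expected. Compound 4 is estimated at 9000 nM, with a range from 3000 nM to 27000 nM expected.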

Compound 4, half-maximal inhibitory concentration: 26000 nM
Estimate against measurement, compound 4: 2.9-fold (0.46 log units) below, and the stated range covers the measured number.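

In this assay, hydrogen in place of methoxy on an aromatic carbon gives a 1.3-fold lower number from compound 3 to compound 4 (0.13 log units; within the scatter), so on the core of compound 3 the change has no effect that can be read beyond the scatter. Set beside the earlier step, the change does not carry over at a single size between these two cores: the same change on two cores in this assay, a 5.3-fold lower number (0.73 log units; beyond the scatter) from compound 2 to compound 1 and a 1.3-fold lower number (0.13 log units; within the scatter) from compound 3 to compound 4, 3.9-fold (0.60 log units) apart, beyond the scatter of two such steps. This shows that a step read on the core of compound 1 cannot be transferred directly to the core of compound 4, but it rests on two pairs only and does not show why the steps differ, since the pairs differ both in which methoxy leaves and in whether methyl or ethyl sits on the amide-type nitrogen.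

Still open, going by these compounds, is whether an ethyl counterpart of compound 1 or a methyl counterpart of compound 4 would separate those two differences. Also open, on these data alone, is how the two cores would respond to a hydroxyl group, an amine or a longer chain at these places.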